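Replacing a phenyl with cyclopropylmethoxy on the arylmethyl amine

A few compounds are considered here, and "the series" means these few. Any claim that something is new, unique, unknown or untested is made for them only; others in the source may bear on it.

Of the compounds shown here, three have been measured in a functional assay on the whole organism with Mus musculus as the target; a higher number here means that more compound is needed for the effect, a lower number that less compound is needed. Compound 1 `CNC(=O)[C@@H](NCc1ccc(OCc2ccccc2)cc1)C(C)C` gives 55.4 mg/kg, compound 2 `CNC(=O)[C@@H](CC(C)C)NCc1ccc(OCc2ccccc2)cc1` gives 192 mg/kg, and compound 3 `C[C@@H](NCc1ccc(-c2ccccc2)cc1)C(N)=O` gives 231 mg/kg. Compound 3 thus stands at the highest of the three numbers; its value sits within the scatter of that of compound 2, so the two cannot be ordered, while it lies beyond the scatter above that of compound 1.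

The step to compound 4 `C[C@@H](NCc1ccc(OCC2CC2)cc1)C(N)=O` changes one place on the core of compound 3: cyclopropylmethoxy in place of phenyl on an aromatic carbon. The group entering is cyclopropylmethoxy, set on an aromatic carbon para to a group of 7 heavy atoms, where phenyl stood before. Compound 4 has not yet been measured.

Among the measured compounds shown here, no measured pair isolates this change, so the expected step from compound 3 to compound 4 in this assay rests on little. He expects a small step downward, a 1.5-fold lower number from compound 3 to compound 4 (0.19 log units; within the scatter), on the grounds that compound 1, which also carries an oxygen-linked group at that place, gives 55.4 mg/kg. For compound 4 he estimates 150 mg/kg, with a range from 60 mg/kg to 400 mg/kg.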

Compound 4, dose for half-maximal effect: 124 mg/kg
The estimate for compound 4 lay 1.2-fold (0.08 log units) above the measured number; the range from low to high includes it.
By their numbers in this assay, from the lowest: compound 1; then compounds 4, 2 and 3 (each within the scatter of the next).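

In this assay the exchange of phenyl for cyclopropylmethoxy on an aromatic carbon gives a 1.9-fold lower number from compound 3 to compound 4 (0.27 log units; within the scatter) and is the first step among these compounds that isolates a single place. This position therefore accepts the loss of the six-membered aromatic ring and the entry of a three-membered ring with an ether oxygen, and compound 3 and compound 4 cannot be ordered. Nothing measured here accounts for this result.

The compounds shown leave open whether any group at this place on the shared core would move the number beyond the scatter, such as a shorter ether like methoxy, a longer chain like butoxy, or an amine. They also leave open whether the same exchange behaves alike on the cores of compound 1 and compound 2.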